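The source may report more compounds than this note shows. Statements on the series, on what has been measured and on what is new or still open speak of the compounds shown alone.

Measured so far:
- compound 1 `CCc1ccc(NC(=O)CSc2nc(Nc3ccccc3)c3ccccc3n2)cc1`: > 50000 nM
- compound 2 `O=C(CSc1nc(Nc2ccccc2)c2ccccc2n1)Nc1ccc(F)c(Cl)c1`: 20900 nM
- compound 3 `C=CC(=O)Nc1cccc(NC(=O)CSc2nc(Nc3ccccc3C)c3ccccc3n2)c1`: 30200 nM

In a functional assay on MGC-803 cells (Homo sapiens) for inhibition, read by MTT assay, with a stated time of 72 h (on this read-out higher numbers stand for weaker inhibition and lower numbers for stronger inhibition), compound 1 gives > 50000 nM, which is a limit of the assay and not a number (the limit of > 50000 nM in this assay, at which 1 of the 3 values shown sits). Compound 2 gives 20900 nM and compound 3 gives 30200 nM. Of the two numbers compound 3 is the higher, but its gap to compound 2 lies within the scatter, so no order between them can be read. Within the data shown here, the only step between measured compounds is an at least 2.3-fold lower number from compound 1 to compound 2 (0.37 log units; beyond the scatter), a change on an amide-type nitrogen.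

Compound 4 `C=CC(=O)Nc1cccc(NC(=O)CSc2nc(Nc3ccc(Br)cc3)c3ccccc3n2)c1` is not yet measured. It differs from compound 3 by 4-bromophenyl in place of 2-methylphenyl on a nitrogen on an aromatic ring. No measured step touches this nitrogen; the single step shown concerns the amide-type nitrogen and so does not bear on this change. With nothing pointing either way, compound 4 is expected to stay close to compound 3. For compound 4 the expected step is a 1.2-fold lower number from compound 3 to compound 4 (0.08 log units; within the scatter), within the scatter. Compound 4 is estimated at 25000 nM, with a range from 8000 nM to 80000 nM, and a return as a limit is possible.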

Compound 4, half-maximal inhibitory concentration: 11500 nM
Compound 4: middle estimate off by 2.2-fold (0.34 log units), on the high side; low and high end bracket the measured number.
By their numbers in this assay, from the lowest: compounds 4, 2 and 3 (each within the scatter of the next, the first and the last beyond it). At a limit, above all of these: compound 1.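

In this assay the read-out responds to the group on the nitrogen on an aromatic ring, and not only to the group on the amide-type nitrogen: 4-bromophenyl in place of 2-methylphenyl gives a 2.6-fold lower number from compound 3 to compound 4 (0.42 log units; beyond the scatter) as a modest step. Both groups count 7 heavy atoms and no hydrogen-bond donors or acceptors, so these counts do not separate them. Nothing at hand gives a cause for this step.

The change replaces methyl with bromine and also alters where the substituent sits on the ring, and the compounds shown do not separate these two changes. Also open, as far as these compounds go, is how 4-methylphenyl, or a phenyl ring carrying an amine, would read on this nitrogen.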